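The compounds below may be only part of what the source reports. "The series", "measured", "known", "first", "only" and "open" are said of these compounds alone.

Measured in a functional assay on AGS cells (Homo sapiens) for antiproliferative activity, read by MTT assay, with a stated time of 48 h; a higher number here means a weaker inhibitor of growth, a lower number a stronger inhibitor of growth:
- compound 1 `COc1ccccc1OCCNc1cnn(Cc2ccc(OC)c(OCC3CC3)c2)c(=O)c1Cl`: > 100000 nM
- compound 2 `COc1ccc(Cn2nc(NCCOc3ccccc3OC)ccc2=O)cc1Br`: > 100000 nM
- compound 3 `COc1ccccc1OCCNc1cnn(Cc2ccc(OC(F)F)c(OCC3CC3)c2)c(=O)c1Cl`: > 100000 nM

Each of these entries is a limit of the assay and not a number. Compound 1 gives only the limit > 100000 nM, so no exact figure places it. The whole set so far comes down to the limit of > 100000 nM in this assay, at which 3 of the 3 values shown sit.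

Compound 4 `COc1ccccc1OCCNc1cnn(Cc2ccc(OC)c(-c3cccc(Cl)c3)c2)c(=O)c1Cl` keeps the core of compound 1 and changes one group: 3-chlorophenyl in place of cyclopropylmethoxy on an aromatic carbon. The 3-chlorophenyl takes the place of cyclopropylmethoxy on an aromatic carbon, ortho to a methoxy group.

Among the compounds with values here, the only measured step is a step that the two limits leave unreadable from compound 1 to compound 3. It concerns a different group and has no readable size, so it offers no size or direction to carry over. In this assay, no step beyond the scatter is therefore expected, and another limit is the likeliest report.

For compound 4 the estimated value is 100000 nM, with an expected range of 30000 nM to 300000 nM. This estimate means an expected a number no higher from compound 1 to compound 4 (the limit leaves the size open).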

Compound 4, concentration for 50% growth inhibition: > 100000 nM
Compound 4: only a limit was reported (the forecaster's own chance of this, stated with the estimate: 75%); the middle value lies on the limit itself.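

Within the data shown here, compound 1 and compound 4 are each reported only as a limit of the assay and not as a number, so no step between them can be read. The set as a whole shows the same: the limit of > 100000 nM in this assay, at which 4 of the 4 values shown sit.

The compounds shown leave open how strongly any of them inhibits growth, and whether any of these changes of group alters that.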